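Swapping the bromophenyl ketone for a furan ketone

The compounds below may be only part of what the source reports. "The series", "measured", "known", "first", "only" and "open" are said of these compounds alone.

Two compounds share a common core. Compound 1, `COc1cc(-c2nnc3n2NC(c2ccco2)C(C(=O)c2ccc(Br)cc2)S3)cc(OC)c1OC`, was tested in a functional assay on MCF7 cells (Homo sapiens) for cytotoxicity, read by MTT assay, with a stated time of 48 h; a lower number here means a stronger inhibitor, a higher number a weaker inhibitor. In this assay compound 1 gives > 100000 nM, which is a limit of the assay rather than a number. Compound 2, `COc1cc(-c2nnc3n2NC(c2ccco2)C(C(=O)c2cccc(Br)c2)S3)cc(OC)c1OC`, in this assay gives 91800 nM. Among the compounds with values here, the only measured step, an at least 1.0-fold lower number from compound 1 to compound 2 (0.03 log units; that floor lies within the scatter), moves the bromine around the phenyl ring and lies within the scatter; its floor follows from the limit of > 100000 nM in this assay, at which 1 of the 2 values shown sits. Among the values shown, compound 2 therefore holds the only real number, the other being a limit. Compound 3, `COc1cc(-c2nnc3n2NC(c2ccco2)C(C(=O)c2ccco2)S3)cc(OC)c1OC`, differs from compound 2 by furan-2-yl in place of 3-bromophenyl on a carbonyl carbon. Within the data shown here, no measured step removes the bromophenyl altogether, so the small step from compound 1 to compound 2 is the only guide and bears on it loosely. For compound 3 a step of a 1.1-fold higher number from compound 2 to compound 3 (0.04 log units; within the scatter) is expected, nothing beyond the scatter. Compound 3 is estimated at 100000 nM, between 30000 nM and 300000 nM.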

Compound 3, half-maximal inhibitory concentration: > 100000 nM
Compound 3: no number, only a limit (the forecaster's own chance of this, stated with the estimate: 50%); the middle value sits exactly at the limit.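

In this assay, putting furan-2-yl in place of 3-bromophenyl on a carbonyl carbon gives an at least 1.0-fold higher number from compound 2 to compound 3 (0.03 log units; that floor lies within the scatter). Compound 3 gives > 100000 nM, which is a limit of the assay and not a number. This position has now carried a five-membered aromatic ring without bromine as well as six-membered aromatic rings with bromine, and the change of ring brings no readable gain in cytotoxicity, with most of the series sitting at one ceiling: the limit of > 100000 nM in this assay, at which 2 of the 3 values shown sit.

The step from compound 1 to compound 3 cannot be read, with a limit on both sides. On these data alone, whether an amine or a carboxylic acid in place of the aromatic ring on this carbonyl carbon would give a clear number in this assay stays open.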